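Notes on an aryl-substituent change in a hydrazone series

The compounds below may be only part of what the source reports. "The series", "measured", "known", "first", "only" and "open" are said of these compounds alone.

The three measured compounds share one core and differ only in the group on the sulfur: compound 1 `Cc1nnc(SCC(=O)N/N=c2/scc(-c3ccc(F)cc3)n2-c2ccccc2)s1`, compound 2 `O=C(CSc1nnnn1-c1ccccc1)N/N=c1/scc(-c2ccc(F)cc2)n1-c1ccccc1` and compound 3 `O=C(CSc1ncccn1)N/N=c1/scc(-c2ccc(F)cc2)n1-c1ccccc1`. In a functional assay on C6 cells (Rattus norvegicus) for cytotoxicity, read by MTT assay, with a stated time of 24 h, tested at 25 ug/mL (a higher number here means a weaker effect of the compound at the concentration tested, a lower number a stronger effect), compound 1 gives 50.1%, compound 2 gives 49.3% and compound 3 gives 63.9%. Compound 2 has the lowest of the three numbers; the step of a number 0.8 percentage points lower from compound 1 to compound 2 (within the scatter) lies within the scatter, while a number 14.6 percentage points higher from compound 2 to compound 3 (beyond the scatter) and a number 13.8 percentage points higher from compound 1 to compound 3 (beyond the scatter) lie beyond it.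

Compound 4 `N#Cc1ccc(-c2cs/c(=N/NC(=O)CSc3nnnn3-c3ccccc3)n2-c2ccccc2)cc1` is not yet measured. It differs from compound 2 as follows: cyano in place of fluoro on an aromatic carbon. Within the data shown here, none of the measured steps bears on this change; all three exchange the group on the sulfur and leave the 4-fluorophenyl untouched. With no step of this kind in hand, no movement beyond the scatter is expected in this assay in either direction. The expected step is a number 0.3 percentage points lower from compound 2 to compound 4 (within the scatter). For compound 4 in this assay the estimate is 49%, with a range from 35% to 63%.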

Compound 4, a percentage reported as activity, at one concentration (the size of the read-out at that concentration, not a potency): 64.2%
For compound 4 the middle estimate is 15.2 percentage points below the measured one, outside the stated range (above it).
By their numbers in this assay, from the lowest: compounds 2 and 1 (each within the scatter of the next); then compounds 3 and 4 (each within the scatter of the next).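

In this assay, the 4-fluorophenyl position proves responsive: cyano in place of fluoro, para to a large group on the aromatic ring, gives a number 14.9 percentage points higher from compound 2 to compound 4 (beyond the scatter), a modest step towards a weaker effect at the concentration tested. Among these compounds, this is the first sign that a change away from the group on the sulfur can move the read-out, here with the 1-phenyl-1H-tetrazol-5-yl group held constant. Nothing on hand explains the step.

From the compounds shown here alone, the 4-cyanophenyl group appears here only with 1-phenyl-1H-tetrazol-5-yl on the sulfur, so it remains open whether the step carries over to the 5-methyl-1,3,4-thiadiazol-2-yl or pyrimidin-2-yl compounds. Also open, going by these compounds, is how an amine or a carboxylic acid at this same aromatic carbon would read, and whether any group there would give a stronger effect than fluoro.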